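Swapping the Aryl Partner: Unbound Fraction

The source may hold more compounds than are shown below. What is called first, only, known or untested is meant among the compounds shown, and "the series" means these compounds.

Of the compounds shown here, three have been measured in an ADME assay on a cell-free system (plasma, Homo sapiens); on this read-out lower numbers stand for a smaller free fraction and higher numbers for a larger free fraction. Compound 1, `CC(Nc1ncnc2[nH]cnc12)c1ccc2cccnc2c1-c1cccc(F)c1`, gives 0.1. Compound 3, `C[C@H](Nc1ncnc2[nH]cnc12)c1cc(Cl)c2cccnc2c1-c1cccc(F)c1`, gives 0.014. Compound 2, `COc1c([C@H](C)Nc2ncnc3[nH]cnc23)cc(Cl)c(C)c1-c1ccc(S(C)(=O)=O)cc1`, gives 0.013, the lowest of the three numbers shown, although compound 3 sits within the scatter of it; compound 1 is the furthest away, with a higher number that lies beyond the scatter. No two of these compounds differ in only one place, so no single step can be read from the measured set.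

Compound 4, `COc1c([C@H](C)Nc2ncnc3[nH]cnc23)cc(Cl)c(C)c1-c1cnn(C)c1`, has not yet been measured in this assay. It differs from compound 2 in one place: 1-methyl-1H-pyrazol-4-yl in place of 4-(methylsulfonyl)phenyl on an aromatic carbon. A five-membered aromatic ring with 2 hetero atoms thus replaces a six-membered aromatic ring of carbon only, on the aromatic carbon ortho to a methoxy group, ortho to a methyl group and meta to a chloro group. Nothing measured here shows what such a swap does to the unbound fraction. A modest rise is expected, a 2.3-fold higher number from compound 2 to compound 4 (0.36 log units; beyond the scatter), at about the edge of the scatter. Anchored on compound 2 at 0.013, compound 4 is estimated at 0.03, with a range from 0.012 to 0.07.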

Compound 4, unbound fraction: 0.029
The estimate for compound 4 lay 1.0-fold (0.01 log units) above the measured number, within the range that was stated.
By their numbers in this assay, from the lowest: compounds 2 and 3 (each within the scatter of the next); then compound 4; then compound 1.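

In this assay, among these compounds, the swap of 4-(methylsulfonyl)phenyl for 1-methyl-1H-pyrazol-4-yl gives a 2.2-fold higher number from compound 2 to compound 4 (0.35 log units; beyond the scatter), the first single change that can be read in this set. It shows that the group on this aromatic carbon, ortho to a methoxy group and ortho to a methyl group, has a modest bearing on the unbound fraction in this series, although the shift is not large. No measured finding here accounts for the shift, so it stands as an observation without an explanation.

Among the compounds shown here, the single swap alters the ring size, the ring atoms and the substituent together, so it remains open whether the shift belongs to the five-membered ring, to the methyl group on it or to the departure of the methylsulfonyl group; a pyrazole without that methyl group, or a plain phenyl ring or one carrying a nitrile or an amine, would separate these. As far as these compounds go, it also remains open whether the same swap moves the unbound fraction in a similar way on the core of compound 3.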